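A few compounds are considered here, and "the series" means these few. Any claim that something is new, unique, unknown or untested is made for them only; others in the source may bear on it.

Compound 1 `CC(C)(C)c1conc1N1C(=O)CSC1c1cccc(C(=O)NCCCCc2ccccc2)c1`: > 1000 nM (a limit, not a number)
Compound 2 `C#Cc1cccc(N2C(=O)CSC2c2cccc(C(=O)NCCCCc3ccccc3)c2)c1`: 149 nM

For the measured compounds named here, in a functional assay on HOS-TE85 cells (Homo sapiens) for inhibition, read by CCK-8 assay, with a stated time of 72 h (on this read-out lower numbers stand for stronger inhibition and higher numbers for weaker inhibition), compound 2 gives 149 nM, the only exact number so far. Compound 3 `COc1c(F)cccc1N1C(=O)CSC1c1cccc(C(=O)NCCCCc2ccccc2)c1` differs from it as follows: 3-fluoro-2-methoxyphenyl in place of 3-ethynylphenyl on an amide-type nitrogen in a ring. Going by the values given here, one measured step bears on this change, made at the same place: an at least 6.7-fold lower number from compound 1 to compound 2 (0.82 log units; beyond the scatter). It shows that the group there can matter, although it involved a different kind of ring. Compound 3 keeps a six-membered aromatic ring of carbon only, but loses the 3-ethynylphenyl group. A modest move towards weaker inhibition is therefore expected, an estimated 2.0-fold higher number from compound 2 to compound 3 (0.30 log units; within the scatter). For compound 3 the expected value is 300 nM, with an estimated range from 80 nM to 1000 nM.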

Compound 3, half-maximal inhibitory concentration: 26.2 nM
The estimate for compound 3 lay 11-fold (1.06 log units) above the measured number; measured number outside the range, below it.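

Putting 3-fluoro-2-methoxyphenyl in place of 3-ethynylphenyl gives a 5.7-fold lower number from compound 2 to compound 3 (0.75 log units; beyond the scatter), so at this place on the amide-type nitrogen, two groups that both keep a six-membered aromatic ring of carbon only can still differ beyond the scatter. Against the five-membered ring of compound 1 the change reads an at least 38-fold lower number from compound 1 to compound 3 (1.58 log units; beyond the scatter), which is a bound and not an exact size, since compound 1 carries a limit and not a number: the limit of > 1000 nM in this assay, at which 1 of the 3 values shown sits. The compounds shown leave open whether the methoxy or the fluorine carries the gain, since the two arrive together. On these data alone, how an amine or a carboxylic acid on this aromatic ring would read also stays open.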